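A few compounds are considered here, and "the series" means these few. Any claim that something is new, unique, unknown or untested is made for them only; others in the source may bear on it.

All four compounds share one core and differ only in the substituent on the outer benzene ring. Compound 1 `Nc1cccc(/C=C2\SC(=O)N(Cc3cccc(F)c3)C2=O)c1` carries fluoro, compound 2 `Nc1cccc(/C=C2\SC(=O)N(Cc3cccc(Cl)c3)C2=O)c1` chloro, compound 3 `Nc1cccc(/C=C2\SC(=O)N(Cc3ccc(C(F)(F)F)cc3)C2=O)c1` trifluoromethyl, and the not yet measured compound 4 `Nc1cccc(/C=C2\SC(=O)N(Cc3ccc(Cl)cc3)C2=O)c1` chloro as well. In a functional assay on HeLa cells (Homo sapiens) for cytotoxicity, read by cell counting, with a stated time of 4 days (a higher number here means a weaker inhibitor, a lower number a stronger inhibitor), compound 1 gives only a limit, > 250000 nM. Compound 2 gives 250000 nM in this assay. Compound 3 likewise reaches only a limit, > 250000 nM, in this assay, so for compound 3 no number is known, only this limit. The change on the way to compound 4 is chloro in place of trifluoromethyl on an aromatic carbon. Going by the values given here, the one measured step that resembles it, a number no higher from compound 1 to compound 2 (the limit leaves the size open), swaps one halogen for another, and its size cannot be read because of the limit of > 250000 nM in this assay, at which 2 of the 3 values shown sit. Among the compounds with values here, no measured step shows how chloro and trifluoromethyl compare, so no size can be given in advance; a weak result is expected, close to compound 2 with 250000 nM. For compound 4 the expected value is 250000 nM, between 120000 nM and 600000 nM. This estimate means a step of a number no higher from compound 3 to compound 4 (the limit leaves the size open), expected to stay near the limit.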

Compound 4, half-maximal inhibitory concentration: > 250000 nM
Compound 4 gave a limit, no number; the forecaster's own chance of this, stated with the estimate: 60%; the middle value lies on the limit itself.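

Exchanging 3-chlorophenyl for 4-chlorophenyl gives a number no lower from compound 2 to compound 4 (the limit leaves the size open), so this move of the chloro group brings no stronger inhibition in this assay. At the position para to a large group, neither trifluoromethyl in compound 3 nor chloro in compound 4 gives a number, only a limit. The other new steps cannot be read, because both compounds in each sit at the same limit: the limit of > 250000 nM in this assay, at which 3 of the 4 values shown sit.

The compounds shown leave open whether any substituent on the outer benzene ring can bring a measurable value in this assay. An amine or a carboxylic acid on that ring, or a longer chain linking it to the shared core, might answer this, but nothing here indicates which way such a change would go.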